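The compounds below may be only part of what the source reports. "The series", "measured", "known", "first", "only" and "open" are said of these compounds alone.

Measured so far in an assay on membranes from HeLa cells for displacement of a labelled ligand from adenosine receptor A3 (Homo sapiens), read by scintillation counting, with a stated time of 180 min, tested at 1 uM; a lower number here means less inhibition, a higher number more inhibition at the concentration tested (going by the name of the read-out):
compound 1 `CCCOC(=O)C1=C(C)NC(=O)NC1c1ccoc1`: 11%
compound 2 `CC(=O)C1=C(C)NC(=O)NC1c1ccoc1`: 2%
compound 3 `CCSC(=O)C1=C(C)NC(=O)NC1c1ccoc1`: 1%

All three numbers sit low and within the scatter of one another: a number 9 percentage points lower from compound 1 to compound 2 (within the scatter), a number 10 percentage points lower from compound 1 to compound 3 (within the scatter), a number 1 percentage points lower from compound 2 to compound 3 (within the scatter). Compound 3 therefore stands with the other two, none of the three separated from it by more than the scatter.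

Compound 4 `CC1=C(C(=O)SC(C)C)C(c2ccoc2)NC(=O)N1` differs from compound 3 by methyl in place of hydrogen on a saturated chain carbon bound to a saturated chain carbon and a sulfur. Within the data shown here, no measured step alters the chain on the sulfur; the steps that touch the group on the carbonyl carbon, from compound 1 and compound 2 to compound 3, were both within the scatter. The expectation for compound 4 in this assay is thus a step of no size beyond the scatter, a number 3 percentage points higher from compound 3 to compound 4 (within the scatter), and the number for compound 4 is estimated at 4%, in the range 0% to 13%.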

Compound 4, a percentage reported as inhibition, at one concentration (the size of the read-out at that concentration, not a potency): 3%
The estimate for compound 4 lay 1 percentage points above the measured number, within the range that was stated.
By their numbers in this assay, from the lowest: compounds 3, 2, 4 and 1 (each within the scatter of the next).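

In this assay, among these compounds, ethylsulfanyl to isopropylsulfanyl gives a number 2 percentage points higher from compound 3 to compound 4 (within the scatter), the first reading of a change in the chain on the sulfur. Isopropylsulfanyl also stays level with the other groups on the carbonyl carbon, with a number 1 percentage points higher from compound 2 to compound 4 (within the scatter) and a number 8 percentage points lower from compound 1 to compound 4 (within the scatter). No supporting evidence bears on this result.

The compounds shown leave open whether a longer chain on the sulfur, or an amine in its place on the carbonyl carbon, would move the number beyond the scatter.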